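This account rests on a few compounds, and the source may have more. Where it says the series, first, only, none or still open, it means among the compounds named here.

In a functional assay on HBL-100 cells (Homo sapiens) for antiproliferative activity, read by luminescence and CellTiter-Glo, with a stated time of 48 h (a lower number here means a stronger inhibitor, a higher number a weaker inhibitor), compound 1 (`O=C1CCC[C@@H]([C@H]2C[C@@H]2c2ccccc2)O1`) reaches only a limit, > 100000 nM. Its mirror image, compound 2 (`O=C1CCC[C@H]([C@@H]2C[C@H]2c2ccccc2)O1`), also gives only a limit, > 100000 nM. Compound 2 therefore has no numerical position on this scale, and the same holds for the pair as a whole: the limit of > 100000 nM in this assay, at which 2 of the 2 values shown sit. Compound 3 (`O=C1CCC[C@H]([C@H]2C[C@@H]2c2ccccc2)O1`) keeps the atoms and bonds of compound 2, and (the two compounds have the same atoms and bonds and differ only in configuration as drawn: 2 of 3 stereo elements differ; a stereocentre at a saturated ring carbon is drawn R in compound 2 and S in compound 3; a stereocentre at a saturated ring carbon is drawn R in compound 2 and S in compound 3). Within the data shown here, the one measured step that bears on this change is a step that the two limits leave unreadable from compound 1 to compound 2, which inverts every stereocentre but has no readable size. It offers no evidence that configuration alone moves activity in this assay, though it cannot exclude such an effect. The expected change, a number no higher from compound 2 to compound 3 (the limit leaves the size open), is thus none beyond the scatter, with no direction favoured. For compound 3 the estimated value is 100000 nM, with an expected range from 40000 nM to 200000 nM.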

Compound 3, half-maximal inhibitory concentration: > 100000 nM
Compound 3: only a limit was reported; the forecaster's own chance of this, stated with the estimate: 85%; the middle value sits exactly at the limit.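

In this assay compound 3 gives only a limit, > 100000 nM. Among these compounds, no step linking compound 1, compound 2 and compound 3 can be read. The compounds shown leave open whether configuration alone changes activity in this assay.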